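Furan isomer swap on the compound 1 core

The source may report more compounds than this note shows. Statements on the series, on what has been measured and on what is new or still open speak of the compounds shown alone.

Compound 1 `O=c1[nH]cnc2c1c(-c1ccoc1)cn2[C@@H]1O[C@H](CO)[C@@H](O)[C@H]1O` — 6370 nM
Compound 2 `C#Cc1cn([C@@H]2O[C@H](CO)[C@@H](O)[C@H]2O)c2ncnc(C)c12` — 1110 nM

Of the compounds shown here, two have been measured in a functional assay on HL-60 cells (Homo sapiens) for antiproliferative activity, read by XTT assay, with a stated time of 72 h; on this read-out lower numbers stand for stronger inhibition and higher numbers for weaker inhibition. Compound 1 gives 6370 nM, the highest number of the two. Compound 2 gives 1110 nM, a lower number, and the gap between the two lies beyond the scatter. Among the compounds with values here, compound 2 differs from compound 1 in more than one place, so no single step connects them and nothing about the furan can be read from that pair.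

Compound 3 `O=c1[nH]cnc2c1c(-c1ccco1)cn2[C@@H]1O[C@H](CO)[C@@H](O)[C@H]1O` is not yet measured. It differs from compound 1 by furan-2-yl in place of furan-3-yl on an aromatic carbon. Within the data shown here, no measured pair shows the effect of this change, so its size cannot be taken from the numbers in hand. With the same atoms joined differently and nothing else altered, no movement beyond the scatter is expected in this assay. The expected step of a 1.1-fold lower number from compound 1 to compound 3 (0.03 log units; within the scatter) is therefore small. For compound 3 the estimated value in this assay is 6000 nM, with a range from 2500 nM to 15000 nM.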

Compound 3, half-maximal inhibitory concentration: 2200 nM
Beside the measured number, compound 3's estimate is 2.7-fold (0.44 log units) above it; the measured number lies below the stated range.
By their numbers in this assay, from the lowest: compounds 2 and 3 (each within the scatter of the next); then compound 1.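

In this assay the furan's point of attachment on this aromatic carbon is not silent: furan-2-yl in place of furan-3-yl gives a 2.9-fold lower number from compound 1 to compound 3 (0.46 log units; beyond the scatter) with the same atoms joined differently. Within the data shown here, this is the only single-place step so far, and it shows that the position responds even when the group's counted heavy atoms, hydrogen-bond donors and hydrogen-bond acceptors stay the same. Nothing measured here accounts for the step, so it stands as an observation only.

As far as these compounds go, whether the same furan swap would carry over to another core stays open, as compound 2 differs from compound 1 in more than one place. Also open, from the compounds shown here alone, is how an amine, a carboxylic acid or a longer alkyl chain on this carbon would compare with furan-2-yl.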